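Dropping the Phenyl Group: What Compound 4 May Show

The source may hold more compounds than are shown below. What is called first, only, known or untested is meant among the compounds shown, and "the series" means these compounds.

Measured compounds in an ADME assay on Vero cells (Chlorocebus sabaeus) for cytotoxicity; on this read-out higher numbers stand for lower toxicity in this test and lower numbers for higher toxicity in this test:
compound 1 `CCN(CC)CN1C(=O)/C(=N/NC(N)=S)c2cc(Cl)ccc21` — compound 1 gives > 100000 nM
compound 2 `CCN(CC)CN1C(=O)/C(=N/NC(=S)Nc2ccc(OC)cc2)c2ccccc21` — compound 2 gives 4000 nM
compound 3 `CCN(CC)CN1C(=O)/C(=N/NC(=S)Nc2ccccc2)c2ccccc21` — compound 3 gives 100000 nM

Within the data shown here, the value of compound 1 is a limit of the test, not a number; it is the one value here that sits at that limit (the limit of > 100000 nM in this assay, at which 1 of the 3 values shown sits). Of the two real numbers, compound 3 stands highest, separated from compound 2 by a 25-fold higher number from compound 2 to compound 3 (1.40 log units; beyond the scatter), a change of hydrogen in place of methoxy on an aromatic carbon.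

Compound 4 `CCN(CC)CN1C(=O)/C(=N/NC(N)=S)c2ccccc21` differs from compound 3 by hydrogen in place of phenyl on an amide-type nitrogen. Among the measured compounds shown here, this change sits on the amide-type nitrogen, not on an aromatic carbon, so the single measured step from compound 2 to compound 3 bears on it only loosely. Compound 1, which carries the same amino group, shows only a limit. Compound 4 is therefore expected to stay close to compound 3, with an expected step of no change at the digits printed from compound 3 to compound 4 (within the scatter), none beyond the scatter, and a real chance that the test again reports only a limit. The estimate for compound 4 is 100000 nM, with a range from 30000 nM to 300000 nM.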

Compound 4, minimum cytotoxic concentration: > 100000 nM
Compound 4 gave a limit, no number; the forecaster's own chance of this, stated with the estimate: 50%; the middle value sits exactly at the limit.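

In this assay, replacing anilino with amino on the amide-type nitrogen gives a number no lower from compound 3 to compound 4 (the limit leaves the size open), so this position does not need a phenyl group for the read-out to stay high. The value of compound 4, > 100000 nM, is a limit of the test and not a number. Measured against the 4-methoxyphenyl group at the same position, the change gives an at least 25-fold higher number from compound 2 to compound 4 (1.39 log units; beyond the scatter), which shows that the shared core without any aryl group on this nitrogen does not carry the lower number seen for compound 2.

As far as these compounds go, whether a methyl group or a longer alkyl chain on this nitrogen would keep the read-out high remains open. The step from compound 1 to compound 4 cannot be read, so the effect of chloro on the aromatic carbon also stays open: the limit of > 100000 nM in this assay, at which 2 of the 4 values shown sit.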